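This account rests on a few compounds, and the source may have more. Where it says the series, first, only, none or still open, it means among the compounds named here.

In a functional assay, read by fluorescence and spectrophotometry, with a stated time of 1 h (on this read-out lower numbers stand for an effect already at smaller amounts and higher numbers for an effect only at larger amounts of compound), compound 1 (`O=S(=O)(/C=C/c1ccc(O)c(O)c1)CC1CCC1`) gives 8800 nM and compound 2 (`CCCCCCS(=O)(=O)/C=C/c1ccc(O)c(O)c1`) gives 7300 nM while compound 3 (`O=S(=O)(/C=C/c1ccc(O)c(O)c1)CC1CCCN1`) gives 13800 nM and so stands with the other two, within the scatter of both.

Compound 4 (`O=S(=O)(/C=C/c1ccc(O)c(O)c1)CC1CCCCO1`) carries oxan-2-yl in place of pyrrolidin-2-yl on a saturated chain carbon bound to a sulfonyl sulfur. For the measured compounds named here, no measured compound carries oxan-2-yl, so the only guide is the set of steps at this same place. These are a 1.6-fold higher number from compound 1 to compound 3 (0.20 log units; within the scatter) and a 1.9-fold higher number from compound 2 to compound 3 (0.28 log units; within the scatter) and a 1.2-fold lower number from compound 1 to compound 2 (0.08 log units; within the scatter) and none of them leaves the scatter.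

Cyclobutyl, pentyl and pyrrolidin-2-yl thus give values that cannot be told apart, and no step beyond the scatter is expected in this assay for compound 4. The estimated change is a 1.5-fold lower number from compound 3 to compound 4 (0.16 log units; within the scatter) and is expected to stay within the scatter. Compound 4 is estimated at 9500 nM with an expected range of 4500 nM to 20000 nM as the outer ends.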

Compound 4, half-maximal effective concentration: 10800 nM
Compound 4: middle estimate off by 1.1-fold (0.06 log units), on the low side; the measured number falls inside the stated range.
By their numbers in this assay, from the lowest: compounds 2, 1, 4 and 3 (each within the scatter of the next).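

Oxan-2-yl, a six-membered non-aromatic ring with 0 hydrogen-bond donors, is accommodated on a saturated chain carbon bound to a sulfonyl sulfur without any step leaving the scatter: this assay shows a 1.3-fold lower number from compound 3 to compound 4 (0.11 log units; within the scatter) and a 1.5-fold higher number from compound 2 to compound 4 (0.17 log units; within the scatter) and a 1.2-fold higher number from compound 1 to compound 4 (0.09 log units; within the scatter) for this group. The exchange of pyrrolidin-2-yl, with its nitrogen and hydrogen-bond donor, for a ring with oxygen and no donor therefore gives no readable change, and the four groups at this place cannot be told apart. Nothing at hand explains this flat picture.

The compounds shown leave open whether a carboxylic acid, an open-chain amine or a longer chain at this place would move the number beyond the scatter. They also leave open whether the same flat picture holds on any core other than the shared one.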